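A few compounds are considered here, and "the series" means these few. Any claim that something is new, unique, unknown or untested is made for them only; others in the source may bear on it.

Working notes on the series. In a functional assay on cells (Leukemia cell, Homo sapiens) for cytotoxicity, read by sulforhodamine B assay, with a stated time of 48 h (on this read-out lower numbers stand for stronger inhibition of growth and higher numbers for weaker inhibition of growth), compound 1, `COc1ccc(OC)c(-c2cc(-c3ccccc3)nn2-c2ccc(S(=O)(=O)NC(C)=O)cc2)c1`, gives 7400 nM, and compound 2, `NS(=O)(=O)c1ccc(-n2nc(-c3ccccc3)cc2-c2cc(O)ccc2O)cc1`, gives 49600 nM; compound 2 thus stands at the higher of the two numbers, and since the two compounds differ in more than one place, only the two values themselves can be compared. Compound 3, `CC(=O)NS(=O)(=O)c1ccc(-n2nc(-c3ccccc3)cc2-c2cc(O)ccc2O)cc1`, is not yet measured and differs from compound 2 by acetyl in place of hydrogen on a sulfonamide nitrogen. For the measured compounds named here, no measured pair shows this change on its own, so the size of the step is not fixed by the data; the only hint is that compound 1, which carries the acetyl, gives 7400 nM, a lower number than compound 2, though with a different aryl group. A modest decrease, close to the scatter, is the expectation, and the step of a 1.7-fold lower number from compound 2 to compound 3 (0.22 log units; within the scatter) is estimated accordingly. For compound 3 the estimate in this assay is 30000 nM, with a range from 10000 nM to 90000 nM.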

Compound 3, concentration for 50% growth inhibition: 93600 nM
Compound 3: the middle estimate sits 3.1-fold (0.49 log units) below what was measured, and the stated range ends below it.
By their numbers in this assay, from the lowest: compound 1; then compounds 2 and 3 (each within the scatter of the next).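

Acetyl in place of hydrogen on a sulfonamide nitrogen now stands alone in one step, a 1.9-fold higher number from compound 2 to compound 3 (0.28 log units; within the scatter), so in this assay this change has no readable effect on this core. With the acetyl held in place, 2,5-dihydroxyphenyl in place of 2,5-dimethoxyphenyl on an aromatic carbon gives a 13-fold higher number from compound 1 to compound 3 (1.10 log units; beyond the scatter), the only step shown that lies beyond the scatter, which places the large difference at the aryl group and not at the sulfonamide nitrogen. Nothing at hand accounts for either step.

Still open, on these data alone, is whether the acetyl step would read the same on the core carrying 2,5-dimethoxyphenyl. Also open, as far as these compounds go, is how a longer acyl chain on the sulfonamide nitrogen, or an amine in place of the hydroxyl groups, would read.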